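Methoxy for methyl on the anilino ring of an acid

The source may hold more compounds than are shown below. What is called first, only, known or untested is meant among the compounds shown, and "the series" means these compounds.

Compound 1 `COC(=O)c1c(Nc2ccc(OC)cc2)sc(C(=O)c2ccc(OC)cc2)c1C`: 15.5%
Compound 2 `COc1ccc(C(=O)c2sc(Nc3ccc(C)cc3)c(C(=O)O)c2C)cc1`: "not active" (no number reported)

In a functional assay, with a stated time of 150 min, tested at 25 ug/mL (a lower number here means a weaker effect, a higher number a stronger effect of the compound at the concentration tested), compound 1 gives 15.5%. Compound 2 is reported in this assay only as "not active" (no number reported), so no single number marks where it stands. Compound 3 `COc1ccc(Nc2sc(C(=O)c3ccc(OC)cc3)c(C)c2C(=O)O)cc1` differs from compound 2 by methoxy in place of methyl on an aromatic carbon. Since compound 2 has no number, the size of this step in this assay cannot be computed, and only a change within the scatter is expected. For compound 3 the activity in this assay is estimated at 6%, with a range from 0% to 18%.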

Compound 3, a percentage reported as activity, at one concentration (the size of the read-out at that concentration, not a potency): 38.5%
The estimate for compound 3 lay 32.5 percentage points below the measured number, and the stated range ends below it.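

In this assay compound 3 gives 38.5%, whereas compound 2 is reported only as not active, so on this acid a methoxy para to a large group goes with a measurable effect where methyl gave no number, though the size of that step cannot be read. The methoxy-bearing pair also shows that the acid outdoes the ester, with a number 23 percentage points higher from compound 1 to compound 3 (beyond the scatter). Nothing measured accounts for either difference. As far as these compounds go, whether chloro or an amine on that aromatic carbon would match methoxy, and whether an amide could replace the acid, remains open.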